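Swapping Furan for Thiophene in a Small Ester Series

The source may hold more compounds than are shown below. What is called first, only, known or untested is meant among the compounds shown, and "the series" means these compounds.

Measured compounds and their values:
- compound 1 `COC(=O)C1=C(C)N(C)C(=O)NC1c1ccco1`: 9%
- compound 2 `CCCOC(=O)C1=C(C)N(C)C(=O)NC1c1ccco1`: 8%
- compound 3 `CC1=C(C(=O)OCC(C)C)C(c2ccco2)NC(=O)N1C`: 23%

All three were tested in an assay on membranes from HeLa cells for displacement of a labelled ligand from adenosine receptor A3 (Homo sapiens), read by scintillation counting, with a stated time of 180 min, tested at 1 uM; a lower number here means less inhibition, a higher number more inhibition at the concentration tested (going by the name of the read-out). Compound 1 stands second highest of the three numbers: its nearest neighbour is compound 2, whose value lies within the scatter of it, while compound 3 lies furthest away, beyond the scatter. The measured steps all concern the ester chain on the shared core: a number 1 percentage points lower from compound 1 to compound 2 (within the scatter), a number 14 percentage points higher from compound 1 to compound 3 (beyond the scatter) and a number 15 percentage points higher from compound 2 to compound 3 (beyond the scatter). None of them touches the five-membered ring attached to the saturated ring carbon.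

Compound 4 `COC(=O)C1=C(C)N(C)C(=O)NC1c1cccs1` is the next compound to be tested. It differs from compound 1 in one place: thiophen-2-yl in place of furan-2-yl on a saturated ring carbon. Going by the values given here, since the furan ring is the same in compound 1, compound 2 and compound 3, no measured step tells how this assay responds to that ring being exchanged. Among the compounds with values here, the only guide is the value of compound 1, which is low, and the small spread across the three measured compounds.

On that basis, the step from compound 1 to compound 4 is expected to be a number 3 percentage points higher from compound 1 to compound 4 (within the scatter), not beyond the scatter. Compound 4 is therefore estimated to give 12% in this assay, with a range from 0% to 30%.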

Compound 4, a percentage reported as inhibition, at one concentration (the size of the read-out at that concentration, not a potency): 15%
Compound 4: the middle estimate sits 3 percentage points below what was measured; measured number inside the range.
By their numbers in this assay, from the lowest: compounds 2, 1, 4 and 3 (each within the scatter of the next, the first and the last beyond it).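

In this assay, going by these compounds alone, exchanging furan-2-yl for thiophen-2-yl on the saturated ring carbon gives a number 6 percentage points higher from compound 1 to compound 4 (within the scatter), so this is the first look at a place on the shared core outside the ester chain, and this exchange does not separate the two compounds. Within the data shown here, the two groups have the same count of heavy atoms and are both five-membered aromatic rings with one hetero atom, differing in that sulfur stands where oxygen stood, and at the single concentration tested that swap alone leaves no difference that can be told from the scatter. The data at hand offer no independent measurement that would explain this result or say what the swap does to the compounds.

Still open, going by these compounds, is whether a larger or more different group at this place, such as a phenyl ring or a pyridin-2-yl ring, would shift the number beyond the scatter. Also open, on these data alone, is whether thiophen-2-yl gives a similar result when combined with the ester chain of compound 3, which reached 23% with furan-2-yl in place.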